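A few compounds are considered here, and "the series" means these few. Any claim that something is new, unique, unknown or untested is made for them only; others in the source may bear on it.

Measured in a functional assay on HT cells (Homo sapiens) for antiproliferative activity, read by fluorescence, with a stated time of 72 h; a higher number here means a weaker inhibitor of growth, a lower number a stronger inhibitor of growth:
- compound 1 `CC(C)c1n[nH]c2c(NCc3ccc(-c4ccccn4)cc3)nc(SCCO)nc12`: 48 nM
- compound 2 `CC(O)CSc1nc(NCc2ccc(-c3ccccn3)cc2)c2[nH]nc(C(C)C)c2n1`: 62 nM
- compound 3 `CC(C)c1n[nH]c2c(NCc3ccc(-c4ccccn4)cc3)nc(SCC(O)CN)nc12`: 55 nM

Compound 3 stands level with the other two, as a 1.1-fold higher number from compound 1 to compound 3 (0.06 log units; within the scatter) and a 1.1-fold lower number from compound 2 to compound 3 (0.05 log units; within the scatter) show. Compound 4 `CSc1nc(NCc2ccc(-c3ccccn3)cc2)c2[nH]nc(C(C)C)c2n1` carries hydrogen in place of 2-amino-1-hydroxyethyl on a saturated chain carbon bound to a sulfur, which turns (3-amino-2-hydroxypropyl)sulfanyl into methylsulfanyl: hydrogen in place of 2-amino-1-hydroxyethyl on a saturated chain carbon bound to a sulfur. The nearest evidence is a 1.3-fold higher number from compound 1 to compound 2 (0.11 log units; within the scatter), together with the two steps above, all on this same chain. None of them removes the whole group, so they bear only indirectly, and a step beyond the scatter is not expected. The expected change is a 1.5-fold higher number from compound 3 to compound 4 (0.16 log units; within the scatter). For compound 4 the estimated value is 80 nM, with an expected range of 30 nM to 220 nM.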

Compound 4, concentration for 50% growth inhibition: 783 nM
Compound 4: the middle estimate sits 9.8-fold (0.99 log units) below what was measured; the whole stated range lies below it.
By their numbers in this assay, from the lowest: compounds 1, 3 and 2 (each within the scatter of the next); then compound 4.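

In this assay the changes along this chain had stayed within the scatter, but hydrogen on the saturated chain carbon bound to a sulfur gives large steps: a 14-fold higher number from compound 3 to compound 4 (1.15 log units; beyond the scatter) and a 13-fold higher number from compound 2 to compound 4 (1.10 log units; beyond the scatter) and a 16-fold higher number from compound 1 to compound 4 (1.21 log units; beyond the scatter). Hydroxymethyl at this place, as in compound 1, already holds the level of the two larger groups, and the loss appears only with methylsulfanyl. No measurement offers a reason for this loss. Still open, as far as these compounds go, is whether the hydroxyl or the chain itself counts: an ethylsulfanyl chain, or a 2-aminoethyl chain carrying an amine instead of the hydroxyl, would separate the two.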